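The compounds below may be only part of what the source reports. "The series", "measured", "known", "first", "only" and "open" are said of these compounds alone.

Compound 1 `CC(/C=C/C1=CCCCC1(C)C)=C\C=C\C(C)=C\COC(=O)c1ccccc1O`: 150000 nM
Compound 2 `COc1cc(NC(C)=O)cc(C(=O)OC/C=C(C)/C=C/C=C(C)/C=C/C2=CCCCC2(C)C)c1O`: < 10000 nM (a limit)
Compound 3 `COc1cccc(O)c1C(=O)OC/C=C(C)/C=C/C=C(C)/C=C/C1=CCCCC1(C)C`: 230000 nM

These values come from a toxicity assay on cells (Fibroblast, Homo sapiens) for cytotoxicity; on this read-out lower numbers stand for stronger inhibition and higher numbers for weaker inhibition. Compound 1 has one close neighbour with a real number, and the two sit within the scatter of each other: a 1.5-fold higher number from compound 1 to compound 3 (0.19 log units; within the scatter). Compound 2 is reported only as a limit of the assay, (the limit of < 10000 nM in this assay, at which 1 of the 3 values shown sits), and this gives no exact number to reason from.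

Compound 4 `CC(=O)Oc1ccccc1C(=O)OC/C=C(C)/C=C/C=C(C)/C=C/C1=CCCCC1(C)C` is compound 1 with acetyl in place of hydrogen on an oxygen on an aromatic ring, which turns hydroxy into acetoxy: acetyl in place of hydrogen on an oxygen on an aromatic ring. Among the compounds with values here, no measured compound carries this change. Within the data shown here, the only measured single-place step is a different one, methoxy in place of hydrogen on an aromatic carbon, and a 1.5-fold higher number from compound 1 to compound 3 (0.19 log units; within the scatter) stayed within the scatter. It therefore offers weak guidance, but it gives no reason to expect a large move in this assay, so no shift beyond the scatter is expected.

The expected step is a 1.1-fold lower number from compound 1 to compound 4 (0.03 log units; within the scatter).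

For compound 4 the estimated value is 140000 nM, with an expected range from 45000 nM to 350000 nM.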

Compound 4, half-maximal inhibitory concentration: 150000 nM
Compound 4: middle estimate off by 1.1-fold (0.03 log units), on the low side; the measured number falls inside the stated range.
By their numbers in this assay, from the lowest: compounds 1, 4 and 3 (each within the scatter of the next). At a limit, below all of these: compound 2.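

In this assay, within the data shown here, acetyl in place of hydrogen on this oxygen gives no change at the digits printed from compound 1 to compound 4 (within the scatter) and so shows that the change to acetoxy leaves the reading within the scatter, whereas the only earlier single-place step was on an aromatic carbon. Compound 4 also lies close to the methoxy-bearing compound, with a 1.5-fold lower number from compound 3 to compound 4 (0.19 log units; within the scatter) as the step, so these three compounds cannot be told apart in this assay despite their different groups on the aromatic ring. Nothing shown gives a cause for this lack of movement.

Compound 2 stands at < 10000 nM as a limit of the assay, not as a number, so it cannot be ranked exactly. Also open, going by these compounds, is how this oxygen would read with a longer chain such as butanoyl, or how the position would read with an amine in place of the hydroxy.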